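The source may report more compounds than this note shows. Statements on the series, on what has been measured and on what is new or still open speak of the compounds shown alone.

Compound 1, `CCOc1ccccc1-c1ccc(-c2nc3cnccc3c(N[C@H](CC(C)C)C(N)=O)c2C#N)cc1`, gives 3.4 in a physicochemical assay for lipophilicity, read by HPLC, at pH 7.5; a higher number here means a more lipophilic compound, a lower number a more polar compound. Compound 2, `CCOc1ccccc1-c1ccc(-c2nc3cnccc3c(N[C@H](CC)C(=O)NS(=O)(=O)C3CC3)c2C#N)cc1`, gives 2.3. Compound 3, `CCOc1ccccc1-c1ccc(-c2nc3cnccc3cc2C#N)cc1`, gives 3.8.

Compound 3 stands highest of the three numbers; its nearest neighbour is compound 1 and its furthest is compound 2, both beyond the scatter. The unmeasured compound 4, `CCOc1ccccc1-c1ccc(-c2nc3cnccc3c(N[C@H](CC)C(=O)N(C)C)c2C#N)cc1`, differs from compound 3 in one place: (1-(dimethylcarbamoyl)propyl)amino in place of hydrogen on an aromatic carbon. Among the measured compounds shown here, the measured step that bears on this is the one between compound 1 and compound 3, a number 0.40 log units higher from compound 1 to compound 3 (beyond the scatter), which runs in the opposite direction, removing a (1-carbamoyl-3-methylbutyl)amino group rather than adding a (1-(dimethylcarbamoyl)propyl)amino group. The group that enters in compound 4 is not the same group that leaves in that step, so the size can only be taken as a guide. The step from compound 1 to compound 2, a number 1.10 log units lower from compound 1 to compound 2 (beyond the scatter), concerns a different change and says less here. A modest fall is therefore expected, of about a number 0.30 log units lower from compound 3 to compound 4 (within the scatter), because the earlier step of a number 0.40 log units higher from compound 1 to compound 3 (beyond the scatter) was of that order. Compound 4 is estimated at 3.5, within a range from 3 to 4.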

Compound 4, distribution coefficient: 3.7
Compound 4: middle estimate off by 0.20 log units, on the low side; measured number inside the range.
By their numbers in this assay, from the lowest: compound 2; then compounds 1, 4 and 3 (each within the scatter of the next, the first and the last beyond it).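

In this assay, (1-(dimethylcarbamoyl)propyl)amino in place of hydrogen on an aromatic carbon, opposite the ring nitrogen, gives a number 0.10 log units lower from compound 3 to compound 4 (within the scatter) and so shows that this position can carry this group without a step beyond the scatter. The group on the carbonyl carbon matters far more: dimethylamino in place of (cyclopropylsulfonyl)amino gives a number 1.40 log units higher from compound 2 to compound 4 (beyond the scatter) whereas 1-(dimethylcarbamoyl)propyl in place of 1-carbamoyl-3-methylbutyl on the nitrogen gives only a number 0.30 log units higher from compound 1 to compound 4 (within the scatter) and keeps the two amides within the scatter of each other. No measurement in hand accounts for these steps.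

From the compounds shown here alone, it remains open whether a carboxylic acid on this side chain would fall as far as compound 2 does. Going by these compounds, it is equally open whether a simple amine on the same aromatic carbon would stay within the scatter of compound 3.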